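This account rests on a few compounds, and the source may have more. Where it says the series, first, only, none or still open, it means among the compounds named here.

Measured compounds in the series:

Compound 1, `CSC(=S)N[C@H]1CCOC1=O`: in a functional assay on MGC-803 cells (Homo sapiens) for cytotoxicity, read by MTT assay, with a stated time of 72 h (on this read-out higher numbers stand for weaker inhibition and lower numbers for stronger inhibition), compound 1 gives > 128000 nM, which is a limit of the assay and not a number.
Compound 2, `CCCCCCCCSC(=S)N[C@H]1CCOC1=O`: in this assay compound 2 gives > 128000 nM, again a limit of the assay.
Compound 3, `O=C(CCl)Nc1ccc(C(=O)/C=C/c2ccc(Cl)cc2)cc1`: in this assay compound 3 gives 4960 nM.

Compound 3 therefore holds the only number shown in this assay; the other two values are limits (the limit of > 128000 nM in this assay, at which 2 of the 3 values shown sit), so no step between measured compounds can be computed, and no pattern is claimed beyond the three compounds.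

Compound 4, `O=C(CCl)Nc1ccc(C(=O)/C=C/c2ccc(F)cc2)cc1`, is not yet measured. It differs from compound 3 in one place: fluoro in place of chloro on an aromatic carbon.

Within the data shown here, no measured step covers this change. A single-halogen exchange on an aromatic ring, with no change in ring count, donors, acceptors or charge, is expected to move the read-out in this assay by no more than the usual scatter, or at most a small loss. The estimated step from compound 3 to compound 4 in this assay is a 1.4-fold higher number from compound 3 to compound 4 (0.15 log units; within the scatter). Compound 4 is accordingly expected to give about 7000 nM, within a range of 3000 nM to 20000 nM.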

Compound 4, half-maximal inhibitory concentration: 4680 nM
Compound 4: middle estimate off by 1.5-fold (0.17 log units), on the high side, within the range that was stated.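

In this assay, among these compounds, the change from 4-chlorophenyl to 4-fluorophenyl gives the first step that can be read, a 1.1-fold lower number from compound 3 to compound 4 (0.03 log units; within the scatter), so this read-out does not separate the two halogens. Among the compounds shown here, on this aromatic carbon, para to a large group, either halogen is therefore compatible with a measured number of the same size, which the earlier compounds could not show while compound 3 held the only number. Nothing shown gives a cause for this step, and the limit reached by compound 1 and compound 2 has no bearing on it.

The compounds shown cover only these two halogens at this position, so the outcome with a hydrogen, a methoxy group, an amine or a carboxylic acid there stays open. On these data alone, the chloroacetyl group is common to compound 3 and compound 4, so its contribution, as against a plain acetyl group, also stays open, and steps linking either compound to compound 1 or compound 2 cannot be read.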